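This account rests on a few compounds, and the source may have more. Where it says the series, first, only, none or still open, it means among the compounds named here.

Compound 1 `CSc1ccc(C2=C(c3ccc(O)cc3)C(=O)N3CCCC3C2)cc1`: > 100000 nM (a limit of the assay)
Compound 2 `CSc1ccc(C2=C(c3ccc(C)cc3)C(=O)N3CCCC3C2)cc1`: 6000 nM

Within the data shown here, in a functional assay on M14 cells (Homo sapiens) for cytotoxicity (a higher number here means a weaker inhibitor of growth, a lower number a stronger inhibitor of growth), compound 2 gives 6000 nM, the only exact number so far. Compound 1 stands at the limit of > 100000 nM in this assay, at which 1 of the 2 values shown sits, which is a limit and not a number. Compound 3 `CSc1ccc(C2=C(c3ccc(SC)cc3)C(=O)N3CCCC3C2)cc1` is unmeasured. It carries methylsulfanyl in place of methyl on an aromatic carbon, para to a large group: methylsulfanyl in place of methyl on an aromatic carbon. Among the measured compounds shown here, the one measured step at this place is large, an at least 16-fold lower number from compound 1 to compound 2 (1.22 log units; beyond the scatter), but it removes hydroxy, a group that plays no part in the new change. It therefore gives only weak guidance, and no clear direction is expected in this assay. The expected change is small, a 1.2-fold lower number from compound 2 to compound 3 (0.08 log units; within the scatter). Compound 3 is estimated at 5000 nM, with an expected range of 1500 nM to 20000 nM.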

Compound 3, concentration for 50% growth inhibition: 5000 nM
Estimate against measurement, compound 3: no gap at the digits printed; measured number inside the range.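

In this assay, methylsulfanyl and methyl at this position cannot be told apart: a 1.2-fold lower number from compound 2 to compound 3 (0.08 log units; within the scatter). A second group in place of hydroxy now also gives a large step, so the contrast no longer rests on methyl alone: an at least 20-fold lower number from compound 1 to compound 3 (1.30 log units; beyond the scatter). Compound 1 remains a limit and not a number: the limit of > 100000 nM in this assay, at which 1 of the 3 values shown sits.

The compounds shown leave open how an amine, a carboxylic acid or a longer chain such as ethyl would behave at this position. They also leave open whether methoxy would follow hydroxy or methyl.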